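The compounds below may be only part of what the source reports. "The series", "measured", "known", "first", "only" and "open" are said of these compounds alone.

Compound 1 `CCCCCCCCO[C@@H]1O[C@@H](C)[C@H](OC(=O)CCCCC)[C@@H](O[C@@H]2O[C@@H](C)[C@H](OC(C)=O)[C@@H](OC(=O)CCC)[C@H]2OC(C)=O)[C@H]1O` is one of three glycolipid esters assessed in a functional assay on NCI-H460 cells (Homo sapiens) for antiproliferative activity, read by MTT assay, with a stated time of 48 h (on this read-out lower numbers stand for stronger inhibition and higher numbers for weaker inhibition), where compound 1 gives 32000 nM. On that read-out it stands second highest of the three numbers: compound 2 `CCCCCCCCCCCCO[C@@H]1O[C@@H](C)[C@H](O[C@@H]2O[C@@H](C)[C@H](OC(C)=O)[C@@H](O[C@@H]3O[C@@H](C)[C@H](OC(C)=O)[C@@H](O)[C@H]3OC(C)=O)[C@H]2O)[C@@H](O)[C@H]1O` gives 91000 nM, a higher number beyond the scatter, and compound 3 `CCCCCCCCO[C@@H]1O[C@@H](C)[C@H](OC(=O)CCCCC)[C@@H](O[C@@H]2O[C@@H](C)[C@H](OC(C)=O)[C@@H](O[C@@H]3O[C@@H](C)[C@H](OC(C)=O)[C@@H](OC(C)=O)[C@H]3O)[C@H]2OC(C)=O)[C@H]1O` gives 10000 nM, a lower number also beyond the scatter. The unmeasured compound 4 `CCCCCCCCO[C@@H]1O[C@@H](C)[C@H](OC(=O)CCCCC)[C@@H](O[C@@H]2O[C@@H](C)[C@H](OC(C)=O)[C@@H](OC(=O)CC(C)C)[C@H]2OC(C)=O)[C@H]1O` differs from compound 1 by a single change, (methyl in place of hydrogen on a saturated chain carbon bound to two saturated chain carbons), so that the propylcarbonyl becomes isobutylcarbonyl. Within the data shown here, no comparable step between measured compounds is available, so the step from compound 1 to compound 4 is expected to be small, in either direction, and likely within the scatter: a 1.1-fold lower number from compound 1 to compound 4 (0.03 log units; within the scatter). On this basis compound 4 is estimated at 30000 nM, with a range from 12000 nM to 75000 nM.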

Compound 4, half-maximal inhibitory concentration: 79000 nM
Compound 4: middle estimate off by 2.6-fold (0.42 log units), on the low side; the whole stated range lies below it.
By their numbers in this assay, from the lowest: compound 3; then compound 1; then compounds 4 and 2 (each within the scatter of the next).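

Compound 1 to compound 4 is the only single-place step shown, and in this assay it reads a 2.5-fold higher number from compound 1 to compound 4 (0.39 log units; beyond the scatter). Methyl in place of hydrogen on a saturated chain carbon bound to two saturated chain carbons therefore shifts the number towards weaker inhibition, so this position responds even to this single added carbon. No available evidence accounts for the shift. The compounds shown leave open whether a longer straight chain or an amine at this position would move the number the same way. They also leave open whether the same change would have a similar effect in compound 3.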